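The compounds below may be only part of what the source reports. "The series", "measured", "known", "first", "only" and "open" are said of these compounds alone.

Compound 1 `Oc1ccc(-c2nc3cc(C(F)(F)F)ccc3[nH]2)cc1` is one of two measured analogues that share a core and differ in the substituent pattern on that core. Within the data shown here, in an ADME assay on MT4 cells (Homo sapiens) for cytotoxicity, read by MTT assay, with a stated time of 96 h (a higher number here means that more compound is tolerated, a lower number that less compound is tolerated), compound 1 gives 17000 nM, the highest of the two numbers so far. Its nearest neighbour is compound 2 `Oc1ccc(-c2nc3cc(Cl)c(Cl)cc3[nH]2)cc1`, which in this assay gives 12000 nM; the two values lie within the scatter of each other, so no order between them can be read. Among the measured compounds shown here, no single-point step between measured compounds is available to guide the next move. Compound 3 `CCC(=O)Nc1ccc(-c2nc3cc(C(F)(F)F)ccc3[nH]2)cc1` is unmeasured and differs from compound 1 in one place: propanoylamino in place of hydroxy on an aromatic carbon. For the measured compounds named here, with no comparable step on record, the step from compound 1 to compound 3 in this assay is expected to be small, in no clear direction and not beyond the scatter, which the estimated 1.2-fold higher number from compound 1 to compound 3 (0.07 log units; within the scatter) reflects. Compound 3 is therefore estimated to give 20000 nM in this assay, with a range from 7000 nM to 55000 nM.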

Compound 3, half-maximal cytotoxic concentration: >= 100000 nM
Compound 3: no number, only a limit (the forecaster's own chance of this, stated with the estimate: 25%); at least 5.0-fold (0.69 log units) between middle value and limit.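

Among these compounds, the position para to a large group is not indifferent in this cytotoxicity read-out: putting propanoylamino in place of hydroxy on this aromatic carbon gives an at least 5.8-fold higher number from compound 1 to compound 3 (0.76 log units; beyond the scatter), the first step on record and one beyond the scatter. In this assay compound 3 gives >= 100000 nM, which is a limit of the assay and not a number. The step therefore fixes a direction and a minimum size, and its full size stays unknown because the reading stops at a limit: the limit of >= 100000 nM in this assay, at which 1 of the 3 values shown sits.

The compounds shown leave open which part of the propanoylamino goes with the step, the amide link or the chain. They also leave open whether an amine, an acetylamino group or a longer chain on the same carbon would read alike, and whether the same change would hold on compound 2.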